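Dimethylamino versus diethylamino on the acrylamide chain

This account rests on a few compounds, and the source may have more. Where it says the series, first, only, none or still open, it means among the compounds named here.

Measured so far:
compound 1 `CCN(CC)C/C=C/C(=O)Nc1cc2c(N3CCc4ccccc43)ncnc2cc1OC` gives 3690 nM
compound 2 `COc1cc2ncnc(N3CCCc4ccccc43)c2cc1NC(=O)/C=C/CN(C)C` gives 1750 nM

Both numbers come from a functional assay on PC-3 cells (Homo sapiens) for antiproliferative activity, read by MTT assay, with a stated time of 72 h; on this read-out higher numbers stand for weaker inhibition and lower numbers for stronger inhibition. Of the two, compound 2 stands with the lower number; compound 1 gives a higher one, and that gap lies beyond the usual scatter. The two compounds differ in more than one place, so the pair says nothing about either change on its own.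

Compound 3 `CCN(CC)C/C=C/C(=O)Nc1cc2c(N3CCCc4ccccc43)ncnc2cc1OC` is not yet measured in this assay. It differs from compound 2 by diethylamino in place of dimethylamino on a saturated chain carbon bound to a double-bonded chain carbon. Among the measured compounds shown here, no measured pair isolates this exchange, so the size of its step is open; the expectation is a small change, if any, toward a weaker number, not clearly beyond the scatter. The estimated step from compound 2 to compound 3 is a 1.4-fold higher number from compound 2 to compound 3 (0.15 log units; within the scatter). For compound 3 the expected value in this assay is 2500 nM, in the range 1000 nM to 6500 nM.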

Compound 3, half-maximal inhibitory concentration: 6890 nM
Compound 3: middle estimate off by 2.8-fold (0.44 log units), on the low side; measured number outside the range, above it.
By their numbers in this assay, from the lowest: compound 2; then compounds 1 and 3 (each within the scatter of the next).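

In this assay, diethylamino in place of dimethylamino on a saturated chain carbon bound to a double-bonded chain carbon gives a 3.9-fold higher number from compound 2 to compound 3 (0.60 log units; beyond the scatter), so this position does respond to the exchange, and dimethylamino is the better of the two amines with 1,2,3,4-tetrahydroquinolin-1-yl held fixed. With diethylamino held fixed, 1,2,3,4-tetrahydroquinolin-1-yl in place of 2,3-dihydro-1H-indol-1-yl on an aromatic carbon gives a 1.9-fold higher number from compound 1 to compound 3 (0.27 log units; within the scatter), a step that cannot be told from scatter. Nothing measured on these compounds accounts for the amine step.

Going by these compounds, whether the amine step holds with 2,3-dihydro-1H-indol-1-yl on the aromatic carbon remains open. Also open, on these data alone, is whether a cyclic amine such as piperidine or morpholine on the same chain carbon would read like dimethylamino or like diethylamino.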